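The source may hold more compounds than are shown below. What is called first, only, known or untested is meant among the compounds shown, and "the series" means these compounds.

In a functional assay for antagonist activity, with Cavia porcellus as the target (a higher number here means a weaker inhibitor, a lower number a stronger inhibitor), compound 1 (`CCN(CC)CC#CCCC1SCCCS1`) gives > 10000000 nM, which is a limit of the assay. Compound 2 (`CCN(C)CC#CCCC1SCCCS1`) gives > 10000000 nM, also a limit. For the measured compounds named here, compound 3 (`CN(CC#CCCC1SCCCS1)CCCc1ccccc1`) gives 2980 nM, the only actual number so far. Compound 4 (`CN(CC#CCCC1SCCCS1)CCCCc1ccccc1`) differs from it by benzyl in place of phenyl on a saturated chain carbon, three bonds along the chain from an amine nitrogen, with benzyl in place of phenyl on a saturated chain carbon, three bonds along the chain from an amine nitrogen. The series shows a step that the two limits leave unreadable from compound 1 to compound 2, which offers no guide to size. It also shows an at least 3300-fold lower number from compound 2 to compound 3 (3.52 log units; beyond the scatter), a large step made by adding benzyl to the chain of compound 2. Compound 3 already carries the aromatic ring, so the present change is much smaller and no step beyond the scatter is expected in this assay. The expected step is a 1.5-fold lower number from compound 3 to compound 4 (0.17 log units; within the scatter). For compound 4 the estimated value is 2000 nM, with an expected range of 400 nM to 10000 nM.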

Compound 4, antagonist equilibrium constant: 3430 nM
For compound 4 the middle estimate is 1.7-fold (0.23 log units) below the measured one; the measured number falls inside the stated range.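

Benzyl in place of phenyl on a saturated chain carbon, three bonds along the chain from an amine nitrogen, gives a 1.2-fold higher number from compound 3 to compound 4 (0.06 log units; within the scatter) in this assay and so leaves the number within the scatter. The earlier at least 3300-fold lower number from compound 2 to compound 3 (3.52 log units; beyond the scatter) showed only that adding benzyl to the chain of compound 2 brings a readable number, whereas this pair shows that the number holds when the chain is extended with the aromatic ring kept. Nothing shown accounts for this flat step.

On these data alone, whether a longer chain at this place would also hold the number stays open, as does the effect of a hydroxyl on the aromatic ring. The step between the two limits cannot be read.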